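A few compounds are considered here, and "the series" means these few. Any claim that something is new, unique, unknown or untested is made for them only; others in the source may bear on it.

In an ADME assay on Chem1 cells (Homo sapiens) for cytotoxicity (a higher number here means that more compound is tolerated, a lower number that less compound is tolerated), compound 1 `NCCCCN(C[C@@H]1CN(C(=O)c2ccco2)CCN1)[C@H]1CCCc2cccnc21` gives > 10 uM, which is a limit of the assay and not a number. Compound 2 `NCCCCN(C[C@H]1CN(C(=O)OCc2ccccc2)CCN1)[C@H]1CCCc2cccnc21` gives > 10 uM, and this too is a limit and not a number. The two compounds therefore stand together at the limit of > 10 uM in this assay, at which 2 of the 2 values shown sit, so compound 2 has no exact value to build on. Compound 3 `NCCCCN(C[C@@H]1CN(C(=O)OCc2ccccc2)CCN1)[C@H]1CCCc2cccnc21` keeps the atoms and bonds of compound 2, and the only difference lies in a stereocentre at a saturated ring carbon: the two compounds have the same atoms and bonds and differ only in configuration as drawn: 1 of 2 stereo elements differ; a stereocentre at a saturated ring carbon is drawn S in compound 2 and R in compound 3. Among the compounds with values here, no measured pair here shows what such a change does in this assay, so no shift beyond the usual scatter is expected, in either direction. The expected step, a step that the limit leaves unreadable from compound 2 to compound 3, is therefore small. For compound 3, the estimated value is 15 uM, with an expected range of 8 uM to 40 uM.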

Compound 3, half-maximal toxic concentration: > 10 uM
Compound 3: only a limit was reported (the forecaster's own chance of this, stated with the estimate: 85%); the middle value is on the limit's open side.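

The steps from compound 2 to compound 3 and from compound 1 to compound 3 cannot be read, because each value is a limit and not a number: the limit of > 10 uM in this assay, at which 3 of the 3 values shown sit. On these data alone, what stays open is how far in this assay each compound lies past that limit, and whether configuration matters there.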